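A few compounds are considered here, and "the series" means these few. Any claim that something is new, unique, unknown or untested is made for them only; others in the source may bear on it.

Working notes on the series in a functional assay on NCI-H1975 cells (Homo sapiens) for cytotoxicity, read by CCK-8 assay, with a stated time of 72 h; a lower number here means a stronger inhibitor, a higher number a weaker inhibitor. Compound 1 `COc1ccccc1/C=c1/[nH]c(=O)/c(=C\c2ccccc2OC)n(C)c1=O` gives 16900 nM in this assay. Compound 2 `COc1ccccc1/C=c1/[nH]c(=O)/c(=C\c2cccc(Cl)c2Cl)[nH]c1=O` is reported as "not active" (no number reported) in this assay, with no number. Compound 3 `C=CCn1c(=O)/c(=C\c2cccc(F)c2)[nH]c(=O)/c1=C\c1ccccc1OC` gives 25600 nM in this assay, the higher of the two numbers at hand; compound 1 sits a little lower, but within the scatter, so no order between them is claimed. Compound 4 `C=CCn1c(=O)/c(=C\c2cc(Br)ccc2F)[nH]c(=O)/c1=C\c1ccccc1OC` is the next entry: 5-bromo-2-fluorophenyl in place of 3-fluorophenyl on a double-bonded chain carbon bound to an aromatic carbon. Among the measured compounds shown here, no measured pair in the set shows this change, so its size cannot be read from the data. Compound 4 is expected to stay near compound 3, with a step from a 1.2-fold higher number from compound 3 to compound 4 (0.07 log units; within the scatter) that is estimated to lie within the scatter, and a value of 30000 nM is estimated, ranging from 12000 nM to 80000 nM.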

Compound 4, half-maximal inhibitory concentration: "not active" (no number reported)
Nothing numeric was reported for compound 4; the estimate stays without a comparison.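

Among the compounds shown here, compound 4 is reported as not active without a number, so no step from compound 3 to compound 4 can be read. The compounds shown leave open how far 5-bromo-2-fluorophenyl in place of 3-fluorophenyl shifts the value. No supporting data bear on this result.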